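The source may hold more compounds than are shown below. What is called first, only, known or untested is meant among the compounds shown, and "the series" means these compounds.

Compound 1 `CCN1CCc2c(sc(NC(=O)[C@@H]3CCCN3)c2C(N)=O)C1` is the reference point of this comparison. In a functional assay (strain AB) with Danio rerio as the target, read by microscopy, with a stated time of 1 h (on this read-out lower numbers stand for an effect already at smaller amounts and higher numbers for an effect only at larger amounts of compound), compound 1 gives only a limit of the assay, > 25000 nM. Compound 2 `CCN1CCc2c(sc(N)c2C(N)=O)C1`, with hydrogen in place of (pyrrolidin-2-yl)carbonyl on a nitrogen on an aromatic ring, also returns only a limit in this assay, namely > 25000 nM. The step that the two limits leave unreadable from compound 1 to compound 2 therefore stays unreadable, since both of its ends sit at the limit of > 25000 nM in this assay, at which 2 of the 3 values shown sit. Going by the values given here, compound 3 `CC(C)(C)OC(=O)CCN1CCc2c(sc(NC(=O)Nc3ccc(Cl)cc3)c2C(N)=O)C1` differs from compound 1 in more than one place and is the one member of the set with a measured number: in this assay compound 3 gives 1100 nM.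

Compound 4 `CCN1CCc2c(sc(NC(=O)Nc3cccc(C)c3)c2C(N)=O)C1` has not yet been measured. Relative to compound 1 the change is (3-methylphenyl)amino in place of pyrrolidin-2-yl on a carbonyl carbon. Among the compounds with values here, no measured step covers this change: the single step available, between compound 1 and compound 2, cannot be read, and compound 3, though it also carries an aromatic amine on the carbonyl carbon, differs from compound 4 elsewhere as well. What compound 3 does show is that a member of this family with such an aromatic amine on the carbonyl carbon reaches a measurable value in this assay. Compound 4 is therefore expected to leave the limit region, with an estimated step of an at least 16-fold lower number from compound 1 to compound 4 (1.22 log units; beyond the scatter) toward effect at smaller amounts. Compound 4 is estimated at 1500 nM, within a range from 400 nM to 8000 nM.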

Compound 4, half-maximal effective concentration: 13000 nM
Beside the measured number, compound 4's estimate is 8.7-fold (0.94 log units) below it; measured number above the stated range.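

In this assay, going by these compounds alone, the carbonyl carbon on the amide-type nitrogen now gives the first single change with a measured number at one end: (3-methylphenyl)amino in place of pyrrolidin-2-yl is an at least 1.9-fold lower number from compound 1 to compound 4 (0.28 log units; that floor lies within the scatter). Within the data shown here, this shows that the change brings compound 4 to a measured number without any other alteration to the core of compound 1, which the earlier compounds could not show, since their one single-change step could not be read. The step can still be read only as a floor, and its full size remains unknown, because one of its ends is a limit: the limit of > 25000 nM in this assay, at which 2 of the 4 values shown sit.

The compounds shown leave open whether the methyl group of (3-methylphenyl)amino plays any part, and what an unsubstituted phenylamino, a cyclohexylamino or a plain amino group would give on this same carbonyl carbon. They also leave open how (3-methylphenyl)amino would behave with a longer chain or a carboxylic acid placed elsewhere on the core.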